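The source may report more compounds than this note shows. Statements on the series, on what has been measured and on what is new or still open speak of the compounds shown alone.

Compound 1, `O=C(O)COc1ccc(NCc2cccc(-c3ccccc3Cl)c2)cc1F`, gives 19.3 nM in a functional assay on CHO cells for agonist activity at Free fatty acid receptor 1 (Homo sapiens), read by FLIPR and calcium flux; a higher number here means that more compound is needed for the effect, a lower number that less compound is needed.
Compound 2, `CC(C)c1ccccc1-c1cccc(CNc2ccc(OCC(=O)O)c(F)c2)c1`, gives 86.2 nM in this assay.
Compound 3, `COc1ccccc1-c1cccc(CNc2ccc(OCC(=O)O)c(F)c2)c1`, gives 536 nM in this assay.

Of these three, compound 3 carries the highest number: the step of a 28-fold higher number from compound 1 to compound 3 (1.44 log units; beyond the scatter) is large and the step of a 6.2-fold higher number from compound 2 to compound 3 (0.79 log units; beyond the scatter) is modest, so compound 3 needs more of itself than either of the others. Compound 4, `Cc1cc(O)ccc1-c1cccc(CNc2ccc(OCC(=O)O)c(F)c2)c1`, has not yet been measured. It differs from compound 3 by 4-hydroxy-2-methylphenyl in place of 2-methoxyphenyl on an aromatic carbon. All three measured steps concern the group on this aromatic carbon: a 4.5-fold higher number from compound 1 to compound 2 (0.65 log units; beyond the scatter), a 28-fold higher number from compound 1 to compound 3 (1.44 log units; beyond the scatter) and a 6.2-fold higher number from compound 2 to compound 3 (0.79 log units; beyond the scatter). They show that the methoxy group gives the highest number of the three groups tried, and that exchanging it for another group has moved the number by a modest to large amount. Compound 4 keeps the same atoms but carries a methyl and a hydroxy group in place of the methoxy; nothing measured speaks to the hydroxy group. The step of a 6.0-fold lower number from compound 3 to compound 4 (0.77 log units; beyond the scatter) is therefore expected to be a modest lowering of the number. Compound 4 is estimated at 90 nM, with a range from 20 nM to 400 nM.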

Compound 4, half-maximal effective concentration: 69.6 nM
Beside the measured number, compound 4's estimate is 1.3-fold (0.11 log units) above it; the range from low to high includes it.
By their numbers in this assay, from the lowest: compound 1; then compounds 4 and 2 (each within the scatter of the next); then compound 3.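

In this assay the exchange of 2-methoxyphenyl for 4-hydroxy-2-methylphenyl gives a 7.7-fold lower number from compound 3 to compound 4 (0.89 log units; beyond the scatter) even though the two groups hold the same atoms, so at this position the number depends on how those atoms are arranged and not only on which atoms are present. A group carrying a hydroxy is also tolerated here: the step of a 1.2-fold lower number from compound 2 to compound 4 (0.09 log units; within the scatter) leaves it level with 2-isopropylphenyl, while the step of a 3.6-fold higher number from compound 1 to compound 4 (0.56 log units; beyond the scatter) shows that 2-chlorophenyl still gives the lower number. No measurement at hand offers an explanation for these steps.

The compounds shown leave open which of the methyl and the hydroxy accounts for the step from the methoxy compound. They also leave open how an amine or a carboxylic acid would fare in place of the hydroxy.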